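Methyl in place of trifluoromethyl: notes on compound 3

The source may report more compounds than this note shows. Statements on the series, on what has been measured and on what is new or still open speak of the compounds shown alone.

Measured so far:
compound 1, `CCC(C(=O)N1CCN(c2ccccc2F)CC1)N1C(=O)CCC1=O`: 0%
compound 2, `CCC(C(=O)N1CCN(c2cccc(C(F)(F)F)c2)CC1)N1C(=O)CCC1=O`: 75%

In a functional assay on the whole organism (strain Swiss) with Mus musculus as the target, in the maximal electroshock model, with a stated time of 0.25 h, at a dose of 100 mg/kg by the intraperitoneal route (on this read-out higher numbers stand for a stronger effect at the one dose given and lower numbers for a weaker effect), compound 2 gives 75%, the higher of the two numbers; compound 1 gives 0%, a gap beyond the scatter. Compound 3, `CCC(C(=O)N1CCN(c2cccc(C)c2)CC1)N1C(=O)CCC1=O`, differs from compound 2 in one place: methyl in place of trifluoromethyl on an aromatic carbon. Among the compounds with values here, no step between measured compounds covers this change, so the expectation rests on compound 2 alone. A moderate fall is expected, a number 25 percentage points lower from compound 2 to compound 3 (beyond the scatter), beyond the scatter but well short of the level of compound 1. In this assay compound 3 is expected to give 50%, between 20% and 85%.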

Compound 3, a percentage reported as activity, at one dose (the size of the read-out at that dose, not a potency): 50%
The estimate for compound 3 equals the measured number at the digits printed, and the stated range covers the measured number.
By their numbers in this assay, from the lowest: compound 1; then compound 3; then compound 2.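

In this assay, methyl in place of trifluoromethyl on this aromatic carbon gives a number 25 percentage points lower from compound 2 to compound 3 (beyond the scatter), so the effect at this dose is reduced but does not depend on trifluoromethyl or on any fluorine. With 3-methylphenyl in place of 2-fluorophenyl on the ring amine nitrogen, the result is a number 50 percentage points higher from compound 1 to compound 3 (beyond the scatter), so an aryl group without fluorine can still carry a clear effect. No measurement at hand accounts for either step. As far as these compounds go, whether chlorine, methoxy or plain hydrogen on that carbon would fall nearer compound 2 or compound 3 remains open.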